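Hydroxy replacing methoxy on the benzyl ring of compound 3

The compounds below may be only part of what the source reports. "The series", "measured", "known", "first", "only" and "open" are said of these compounds alone.

Compound 3 `C/C=C/C(=O)N(Cc1ccc(OC)c(OC)c1)c1cc(OC)c(OC)c(OC)c1` gives the highest number of the three measured compounds in a functional assay on MGC-803 cells (Homo sapiens) for inhibition, read by MTT assay, with a stated time of 48 h (on this read-out lower numbers stand for stronger inhibition and higher numbers for weaker inhibition), at 20100 nM; compound 1 `C/C=C/C(=O)N(Cc1ccc(OC)c(C)c1)c1cc(OC)c(OC)c(OC)c1` is within scatter of it at 14500 nM, whereas compound 2 `C/C=C/C(=O)N(Cc1ccc(OC)cc1)c1cc(OC)c(OC)c(OC)c1` sits far lower at 450 nM. The step to compound 4 `C/C=C/C(=O)N(Cc1ccc(OC)c(O)c1)c1cc(OC)c(OC)c(OC)c1` is hydrogen in place of methyl on an oxygen on an aromatic ring, that is methoxy to hydroxy. Going by the values given here, two measured steps bear on it: a 45-fold higher number from compound 2 to compound 3 (1.65 log units; beyond the scatter), and a 1.4-fold higher number from compound 1 to compound 3 (0.14 log units; within the scatter), so a small group in that place has so far cost as much as methoxy. A hydroxy group is expected to behave more like methyl than like hydrogen, so only a modest improvement, a 2.5-fold lower number from compound 3 to compound 4 (0.40 log units; beyond the scatter), is estimated. Compound 4 is expected to give about 8000 nM, ranging from 2000 nM to 30000 nM.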

Compound 4, half-maximal inhibitory concentration: 27 nM
Estimate against measurement, compound 4: 300-fold (2.47 log units) above; the measured number lies below the stated range.
By their numbers in this assay, from the lowest: compound 4; then compound 2; then compounds 1 and 3 (each within the scatter of the next).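

In this assay this place does not penalise every group larger than hydrogen: hydroxy gives a 740-fold lower number from compound 3 to compound 4 (2.87 log units; beyond the scatter) and a 540-fold lower number from compound 1 to compound 4 (2.73 log units; beyond the scatter) against the two groups that had looked equally poor. Hydroxy also beats hydrogen itself, with a 17-fold lower number from compound 2 to compound 4 (1.22 log units; beyond the scatter) in the same direction, so the earlier loss holds for methoxy and methyl only, and compound 4 is the strongest of the series. Nothing available explains this difference between hydroxy and methoxy.

The compounds shown leave open whether an amine or a fluorine in that place would match hydroxy. They also leave open whether the gain survives changes elsewhere on the core.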